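The source may hold more compounds than are shown below. What is called first, only, known or untested is meant among the compounds shown, and "the series" means these compounds.

Compound 1 `Cc1ccc2nc(NC(c3cn(-c4ccccc4)nc3-c3cccc([N+](=O)[O-])c3)c3c(O)ccc4ccccc34)sc2c1`: 7360 nM
Compound 2 `O=[N+]([O-])c1cccc(-c2nn(-c3ccccc3)cc2C(Nc2nc3ccc(Cl)cc3s2)c2c(O)ccc3ccccc23)c1`: 15500 nM

In a functional assay on HeLa cells (Homo sapiens) for antiproliferative activity, read by MTT assay, with a stated time of 48 h (a higher number here means a weaker inhibitor, a lower number a stronger inhibitor), compound 2 gives 15500 nM, the higher of the two numbers, which makes it the weaker inhibitor of this pair. Compound 3 `O=[N+]([O-])c1ccc(-c2nn(-c3ccccc3)cc2C(Nc2nc3ccc(Cl)cc3s2)c2c(O)ccc3ccccc23)cc1` differs from compound 2 in a single group: 4-nitrophenyl in place of 3-nitrophenyl on an aromatic carbon. Put simply, 4-nitrophenyl stands in place of 3-nitrophenyl on an aromatic carbon, so the same atoms are joined differently. Going by the values given here, the only measured step is a 2.1-fold higher number from compound 1 to compound 2 (0.32 log units; beyond the scatter). It is modest and involves chloro in place of methyl elsewhere in the molecule, so it offers only a rough sense of how far one small change can move the number. No measurement shows a direction for the new change, so no step beyond the scatter is expected. The step expected is a 1.2-fold lower number from compound 2 to compound 3 (0.08 log units; within the scatter). For compound 3 the estimated value is 13000 nM, with an expected range of 5500 nM to 30000 nM.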

Compound 3, half-maximal inhibitory concentration: 13400 nM
Compound 3: middle estimate off by 1.0-fold (0.01 log units), on the low side; the measured number falls inside the stated range.
By their numbers in this assay, from the lowest: compounds 1, 3 and 2 (each within the scatter of the next, the first and the last beyond it).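

In this assay, swapping 3-nitrophenyl for 4-nitrophenyl on the aromatic carbon of the five-membered ring gives a 1.2-fold lower number from compound 2 to compound 3 (0.06 log units; within the scatter), so the two arrangements of the same atoms cannot be told apart in this assay. Going by these compounds alone, the earlier pair showed only a change of chloro for methyl elsewhere in the molecule, whereas this step is the first reading at this position, and it shows that relocating the nitro group on this phenyl ring leaves the number within the scatter. No supporting measurement bears on this result, so it stays a plain observation.

Still open, from the compounds shown here alone, is whether this position would respond to a different group on the phenyl ring, such as an amine or a carboxylic acid. Going by these compounds, it is also open whether the same nitro swap would read alike with methyl in place of chloro.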